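Replacing a hydroxy-methyl pyrimidine with a dimethoxy pyrimidine

This account rests on a few compounds, and the source may have more. Where it says the series, first, only, none or still open, it means among the compounds named here.

Measured compounds:
compound 1 `Cc1cc(O)nc(NC(=S)NC(=O)c2c(-c3ccc(Cl)cc3Cl)noc2C)n1`: -9.78%
compound 2 `COc1cc(C)nc2n/c(=N/C(=O)c3c(-c4ccc(Cl)cc4Cl)noc3C)sn12`: 30.9%
compound 3 `COc1cc(Cl)nc(NC(=S)NC(=O)c2c(-c3ccc(Cl)cc3Cl)noc2C)n1`: 18.5%

All three were tested in a functional assay on the whole organism (strain L.) for inhibition, with Echinochloa crus-galli as the target, with a stated time of 72 h, tested at 10 mg/L; on this read-out higher numbers stand for more inhibition of growth at the one concentration tested and lower numbers for less inhibition of growth. Compound 1 stands lowest of the three numbers: compound 3 sits a step above it, and the value of compound 2 lies further above still, though no single-place comparison connects compound 2 with compound 1.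

The compound not yet measured is compound 4 `COc1cc(OC)nc(NC(=S)NC(=O)c2c(-c3ccc(Cl)cc3Cl)noc2C)n1`. It differs from compound 1 in one place: 4,6-dimethoxypyrimidin-2-yl in place of 4-hydroxy-6-methylpyrimidin-2-yl on an amide-type nitrogen.

Going by the values given here, one measured step bears on this change. From compound 1 to compound 3, which also swaps the hydroxy-methyl pyrimidine for a pyrimidine carrying a methoxy group, the step was a number 28.3 percentage points higher from compound 1 to compound 3 (beyond the scatter). Compound 4 carries two methoxy groups on that ring, so a step of similar size and in the same upward direction is expected in this assay, that is roughly a number 29.8 percentage points higher from compound 1 to compound 4 (beyond the scatter). The estimate for compound 4 is therefore 20%, with a range from 0% to 45%.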

Compound 4, percent growth inhibition at one concentration: 21.8%
Estimate against measurement, compound 4: 1.8 percentage points below; low and high end bracket the measured number.
By their numbers in this assay, from the lowest: compound 1; then compounds 3, 4 and 2 (each within the scatter of the next, the first and the last beyond it).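

Putting 4,6-dimethoxypyrimidin-2-yl on the amide-type nitrogen gives a second upward step, a number 31.6 percentage points higher from compound 1 to compound 4 (beyond the scatter), so two different replacement rings at this place now both stand clearly above the hydroxy-methyl ring of compound 1. The swap of methoxy in place of chloro on an aromatic carbon gives a number 3.3 percentage points higher from compound 3 to compound 4 (within the scatter), so this read-out does not separate those two groups on the ring. No measurement shown here explains why these rings score differently from the hydroxy-methyl ring.

Compound 1 differs from the others in both its hydroxy and its methyl group, so it remains open which of the two accounts for its low number. Also open, from the compounds shown here alone, is how the read-out would respond to an amino group or an ethoxy group on that ring.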